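The compounds below may be only part of what the source reports. "The series", "measured", "known", "first", "only" and "open" are said of these compounds alone.

Compound 1 `CC(=O)NCCNC(=O)CCC(=O)Oc1c(C)c(C)c2c(c1C)CCC(C)(COc1ccc(/C=C3\SC(=O)NC3=O)cc1)O2` has been tested in a functional assay on MDA-MB-231 cells (Homo sapiens) for antiproliferative activity, read by luminescence, with a stated time of 24 h; a higher number here means a weaker inhibitor, a lower number a stronger inhibitor. There compound 1 gives > 25000 nM, which is a limit of this assay and not a number. On the scale of the three measured compounds, its place is therefore (the limit of > 25000 nM in this assay, at which 1 of the 3 values shown sits). Two relatives do give numbers: in this assay, compound 2 `Cc1cc(C)c2c(c1C)OC(C)(COc1ccc(CC3SC(=O)NC3=O)cc1)CC2` gives 12300 nM, and compound 3 `Cc1c(C)c2c(c(C)c1OC(=O)CCCCCCCNC(=O)CCCC[C@@H]1SC[C@@H]3NC(=O)N[C@@H]31)CCC(C)(COc1ccc(/C=C3\SC(=O)NC3=O)cc1)O2` gives 3700 nM.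

Compound 4 `Cc1c(C)c2c(c(C)c1OC(=O)CCCCCCCN)CCC(C)(COc1ccc(/C=C3\SC(=O)NC3=O)cc1)O2` has not been measured yet. Compared with compound 1, it carries a changed end on the chain attached through the ester: 5-aminopentyl in place of (2-acetamidoethyl)carbamoyl on a saturated chain carbon, two bonds along the chain from a carbonyl carbon. In plain terms, a 5-aminopentyl group comes in place of (2-acetamidoethyl)carbamoyl, on a saturated chain carbon, two bonds along the chain from a carbonyl carbon.

Going by the values given here, no measured pair shows this change on its own, so any forecast is uncertain. It leans on the numbers that exist, namely compound 3 at 3700 nM and compound 2 at 12300 nM. The expected move is towards stronger inhibition and beyond the usual scatter, with an estimated at least 6.2-fold lower number from compound 1 to compound 4 (0.79 log units; beyond the scatter), although that step starts from a limit. The expected value for compound 4 is 4000 nM, with an estimated range from 1200 nM to 14000 nM.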

Compound 4, half-maximal inhibitory concentration: 5000 nM
Compound 4: middle estimate off by 1.3-fold (0.10 log units), on the low side; measured number inside the range.
By their numbers in this assay, from the lowest: compounds 3 and 4 (each within the scatter of the next); then compound 2. At a limit, above all of these: compound 1.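

In this assay, putting 5-aminopentyl in place of (2-acetamidoethyl)carbamoyl on a saturated chain carbon, two bonds along the chain from a carbonyl carbon, gives an at least 5.0-fold lower number from compound 1 to compound 4 (0.69 log units; beyond the scatter), the first direct sign that the end of this chain affects the read-out. The true size of this step cannot be read, and it is known only as a minimum because the starting point for compound 1 is a limit and not a number: the limit of > 25000 nM in this assay, at which 1 of the 4 values shown sits. Compound 4 also shares its chain with compound 3, which carries a much larger amide-capped end instead of the free amine, and the values of these two lie within the usual scatter of each other, so in this pair the larger cap shows no measurable change.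

The change from compound 1 to compound 4 alters the chain length and the end group together, and the compounds shown do not separate the two. A carboxylic acid or a simple acetamide at the end of the same chain, or a shorter chain that keeps the amine, would help to tell which of them matters.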